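From compound 2 to compound 4: a cyclopropylsulfonyl group

The source may hold more compounds than are shown below. What is called first, only, known or untested is meant among the compounds shown, and "the series" means these compounds.

For the measured compounds named here, only one compound in this small set carries a number. In a functional assay on NCI-H1975 cells (Homo sapiens) for antiproliferative activity, read by MTT assay, with a stated time of 72 h (on this read-out lower numbers stand for stronger inhibition and higher numbers for weaker inhibition), compound 1 (`CN1CCN(c2ccc(Nc3ncc4nc(Nc5ccc(F)cc5)n([C@H]5CCCN(C(=O)CO)C5)c4n3)cc2)CC1`) gives 750 nM. Compound 2 (`CN1CCN(c2ccc(Nc3ncc4nc(Nc5ccccc5)n([C@H]5CCNC5)c4n3)cc2)CC1`), the starting point here, has no number to offer: in this assay compound 2 is recorded as "not determined" (no result reported). The same holds for its close relative, since compound 3 (`CN1CCN(c2ccc(Nc3ncc4nc(Nc5ccc(F)cc5)n([C@H]5CCNC5)c4n3)cc2)CC1`) is recorded as "not determined" (no result reported). Going by the values given here, compound 2 therefore has no rank, and no measured step is available to calibrate a change at this position.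

The next compound for testing is compound 4 (`CN1CCN(c2ccc(Nc3ncc4nc(Nc5ccccc5)n([C@@H]5CCN(S(=O)(=O)C6CC6)C5)c4n3)cc2)CC1`). The structural change is 1-(cyclopropylsulfonyl)pyrrolidin-3-yl in place of pyrrolidin-3-yl on an aromatic nitrogen.

Among the compounds with values here, with no value for compound 2, the size and direction of this step in this assay cannot be derived from the data, and no step is claimed. Within the data shown here, the only anchor is compound 1 at 750 nM, so a result of similar order is expected, with a wide margin on either side. For compound 4 the expected value is 600 nM, with an estimated range of 150 nM to 2500 nM.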

Compound 4, half-maximal inhibitory concentration: 200 nM
Compound 4: middle estimate off by 3.0-fold (0.48 log units), on the high side; low and high end bracket the measured number.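

In this assay, for the compounds shown here, compound 4 gives 200 nM but compound 2 has no single number, so no step between compound 2 and compound 4 can be read. The compounds shown leave open how 1-(cyclopropylsulfonyl)pyrrolidin-3-yl compares with pyrrolidin-3-yl on this core. No evidence bearing on this result is available.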